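A few compounds are considered here, and "the series" means these few. Any claim that something is new, unique, unknown or untested is made for them only; others in the source may bear on it.

Compound 1 `O=C(O)c1ccccc1-c1ccc(CCc2ncc(CC3CCCCCC3)[nH]2)cc1`: 5.7 nM
Compound 2 `O=C(O)c1ccccc1-c1ccc(CCc2ncc(Cc3cccc(F)c3F)[nH]2)cc1`: 8 nM
Compound 3 `O=C(O)c1ccccc1-c1ccc(CCc2ncc(Cc3ccccc3Cl)[nH]2)cc1`: 22 nM

In an in vitro functional assay on cells for agonist activity at Bombesin receptor subtype-3 (Mus musculus), read by luminescence and calcium flux (a lower number here means that less compound is needed, a higher number that more compound is needed for the effect), compound 3 stands at the highest of the three numbers: a 2.8-fold higher number from compound 2 to compound 3 (0.44 log units; beyond the scatter), and a 3.9-fold higher number from compound 1 to compound 3 (0.59 log units; beyond the scatter). Compound 4 `O=C(O)c1ccccc1-c1ccc(CCc2ncc(CC3CCCC3)[nH]2)cc1` differs from compound 3 in one place: cyclopentyl in place of 2-chlorophenyl on a saturated chain carbon bound to an aromatic carbon. Within the data shown here, the measured step that bears on this is the one from compound 1 to compound 3, which ran the other way, a saturated ring of carbon only giving way to 2-chlorophenyl and the number rising beyond the scatter. Cyclopentyl is again a saturated ring of carbon only, so the number is expected to fall back toward that of compound 1, by about a 2.8-fold lower number from compound 3 to compound 4 (0.44 log units; beyond the scatter). Compound 4 is therefore estimated at 8 nM, within a range from 3 nM to 25 nM.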

Compound 4, half-maximal effective concentration: 7.9 nM
For compound 4 the middle estimate is 1.0-fold (0.01 log units) above the measured one; low and high end bracket the measured number.
By their numbers in this assay, from the lowest: compounds 1, 4 and 2 (each within the scatter of the next); then compound 3.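

Cyclopentyl on this saturated chain carbon undoes the rise seen with 2-chlorophenyl (with a 2.8-fold lower number from compound 3 to compound 4 (0.44 log units; beyond the scatter)), so a second saturated ring of carbon only behaves like cycloheptyl. The five-membered ring stays level with cycloheptyl (with a 1.4-fold higher number from compound 1 to compound 4 (0.14 log units; within the scatter)) and with 2,3-difluorophenyl (with a 1.0-fold lower number from compound 2 to compound 4 (0.01 log units; within the scatter)), so among these compounds neither ring size nor an aromatic ring alone sets the number, and only compound 3 stands apart. Nothing measured here gives a cause for these steps. On these data alone, whether cyclopropyl or piperidinyl would hold the number remains open, as does whether unsubstituted phenyl would show that the chlorine drives the rise in compound 3.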